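Compound 4 and the ethoxycarbonyl step from compound 3

The source may report more compounds than this note shows. Statements on the series, on what has been measured and on what is new or still open speak of the compounds shown alone.

Compound 1 `Cc1ccc(S(=O)(=O)C#CC(O/C=C/S(=O)(=O)c2ccc(C)cc2)C(C)C)cc1` gives 3800 nM
Compound 2 `CCOC(=O)C#CC(O/C=C/C(=O)OC)C(C)C` gives 880 nM
Compound 3 `C#CCO/C=C/C(=O)OC` gives > 100000 nM as a limit of the assay

All three compounds were tested in a functional assay on HBL-100 cells (Homo sapiens) for antiproliferative activity, read by sulforhodamine B assay, with a stated time of 48 h (a lower number here means a stronger inhibitor of growth, a higher number a weaker inhibitor of growth), and two of them returned a number. In this test compound 3 stands at > 100000 nM and that entry is a limit, not a number. Its true position is therefore open, and any step that starts from it has an uncertain size.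

Compound 4 `CCOC(=O)C#CCO/C=C/C(=O)OC` departs from compound 3 in one place, with ethoxycarbonyl in place of hydrogen on a triple-bonded carbon and the rest of the structure unchanged. Going by the values given here, no measured pair isolates this change, so the expectation rests on a looser comparison. Compound 2 holds the same ethoxycarbonyl on a triple-bonded carbon and also differs from compound 4 elsewhere. In this assay compound 2 gives 880 nM as a number well within range. A large step towards stronger growth inhibition is therefore expected, beyond the usual scatter. The estimated step is an at least 33-fold lower number from compound 3 to compound 4 (1.52 log units; beyond the scatter) in that direction. Compound 4 is expected at 3000 nM in this assay (estimated range 700 nM to 20000 nM).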

Compound 4, concentration for 50% growth inhibition: 2400 nM
Compound 4: middle estimate off by 1.3-fold (0.10 log units), on the high side; measured number inside the range.
By their numbers in this assay, from the lowest: compound 2; then compounds 4 and 1 (each within the scatter of the next). At a limit, above all of these: compound 3.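

In this assay, ethoxycarbonyl in place of hydrogen on a triple-bonded carbon can now be read as a change in one place, and it gives an at least 41-fold lower number from compound 3 to compound 4 (1.61 log units; beyond the scatter), a step whose true size stays open because it starts from a limit: the limit of > 100000 nM in this assay, at which 1 of the 4 values shown sits.

Among the earlier compounds no pair differed in one place, so only this result ties the ethoxycarbonyl itself to a large step towards stronger growth inhibition. It also opens a second comparison, on a saturated chain carbon bound to an oxygen on an unsaturated carbon and a triple-bonded carbon, where hydrogen in place of isopropyl gives a 2.7-fold higher number from compound 2 to compound 4 (0.44 log units; beyond the scatter), a modest step beyond the scatter that shows compound 4 keeps a measured number without the isopropyl.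

The compounds shown leave open whether another group on the triple-bonded carbon, such as a carboxylic acid, an amide or a nitrile, would give a similar step. They also leave open how a longer chain in place of the ethyl of the ester, or a methyl or a tert-butyl in place of the isopropyl, would read in this assay.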